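A few compounds are considered here, and "the series" means these few. Any claim that something is new, unique, unknown or untested is made for them only; others in the source may bear on it.

Compound 1, `FC(F)(F)c1ccccc1-c1nc(NCc2ccccc2)c2ccccc2n1`: in an assay on a protein complex for inhibition of ubiquitin carboxyl-terminal hydrolase 1/WD repeat-containing protein 48 (Homo sapiens), read by fluorescence (a higher number here means a weaker inhibitor, a lower number a stronger inhibitor), compound 1 gives 3100 nM.
Compound 2, `CC(C)c1ccccc1-c1nc2c(c(NCc3ccc(-c4cccnc4)cc3)n1)CCC2`: in this assay compound 2 gives 160 nM.
Compound 3, `Cc1cnc(-c2ccccc2C(C)C)nc1NCC1CCN(C2COC2)CC1`: in this assay compound 3 gives 13600 nM.

Of these three, compound 3 has the highest number, that is, it is the weakest inhibitor of the set. Its nearest neighbour is compound 1, whose number is lower by more than the usual scatter, and compound 2 lies far below it, with a gap well beyond the scatter.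

Compound 4, `Cc1ccc(N2CCC(CNc3nc(-c4ccccc4C(C)C)ncc3C)CC2)cn1`, has not yet been measured. It differs from compound 3 in one place: 6-methylpyridin-3-yl in place of oxetan-3-yl on an amine nitrogen in a ring. The group that leaves is a small saturated ring; the group that enters is a methyl-bearing aromatic ring, larger by the count given.

Among the measured compounds shown here, no measured pair in this set isolates such a change, so the expectation rests on general comparison only. For the measured compounds named here, compound 2, the only measured compound carrying an aromatic ring at the far end of its side chain, gives the lowest number, while compound 3 does not carry one and gives the highest. On that basis a moderate drop in the number is expected for the step of a 3.9-fold lower number from compound 3 to compound 4 (0.59 log units; beyond the scatter), though a result within the scatter would not surprise. Compound 4 is therefore estimated at 3500 nM, in a range from 800 nM to 14000 nM.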

Compound 4, half-maximal inhibitory concentration: 90 nM
Compound 4: the middle estimate sits 39-fold (1.59 log units) above what was measured; measured number below the stated range.
By their numbers in this assay, from the lowest: compounds 4 and 2 (each within the scatter of the next); then compound 1; then compound 3.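

In this assay the group on the amine nitrogen in a ring turns out to matter a great deal: 6-methylpyridin-3-yl in place of oxetan-3-yl gives a 150-fold lower number from compound 3 to compound 4 (2.18 log units; beyond the scatter) with the rest of the molecule unchanged. Among the compounds shown here, this is the first direct reading at this position, as no earlier pair differed in one place only, and it shows that a larger aromatic ring is accepted here and goes with much stronger inhibition. Nothing shown explains why the number falls so far.

The two groups differ in ring size, in being aromatic or saturated, and in the methyl, so this single step cannot say which of these differences carries the gain. On these data alone, a plain phenyl ring, a pyridin-3-yl ring without the methyl, or a saturated six-membered ring such as tetrahydropyran-4-yl at the same nitrogen would begin to separate them, and it also remains open whether the gain would carry over to other cores.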